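Working notes: the step from compound 3 to compound 4

The compounds below may be only part of what the source reports. "The series", "measured", "known", "first", "only" and "open" are said of these compounds alone.

Measured in a physicochemical assay for solubility, read by HPLC, measured as kinetic solubility, at pH 4; on this read-out lower numbers stand for lower solubility and higher numbers for higher solubility:
- compound 1 `FC(F)(F)c1c(CN2CCC(c3ccccc3)CC2)ccn2c(CC3CC3)nnc12`: > 100000 nM (a limit)
- compound 2 `FC(F)(F)c1c(CN2CCCC(c3ccccc3)C2)ccn2c(CC3CC3)nnc12`: 91000 nM
- compound 3 `Fc1ccccc1C1CCN(Cc2ccn3c(CC4CC4)nnc3c2C(F)(F)F)CC1`: > 100000 nM (a limit)

Compound 3 stands at the limit of > 100000 nM in this assay, at which 2 of the 3 values shown sit, so only a limit is known for it. Compound 4 `Fc1ccc(OC2CCN(Cc3ccn4c(CC5CC5)nnc4c3C(F)(F)F)CC2)c(F)c1` carries 2,4-difluorophenoxy in place of 2-fluorophenyl on a saturated ring carbon. Among the compounds with values here, the one measured step, a step that the two limits leave unreadable from compound 1 to compound 3, concerns a fluoro change and gives no size to carry over. Within the data shown here, the expectation therefore rests mainly on compound 2 at 91000 nM, the only true number. The expected at least 1.1-fold lower number from compound 3 to compound 4 (0.07 log units; that floor lies within the scatter) is no step beyond the scatter, and if anything a slight fall. For compound 4 the estimate is 85000 nM, with an expected range of 35000 nM to 100000 nM.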

Compound 4, solubility: > 100000 nM
Compound 4 ended at the assay's limit; the forecaster's own chance of this, stated with the estimate: 55%; at least 1.1-fold (0.07 log units) between middle value and limit.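

Compound 1, compound 3 and compound 4 all end at a limit, so no step among them can be read: the limit of > 100000 nM in this assay, at which 3 of the 4 values shown sit.

As far as these compounds go, whether 2,4-difluorophenoxy in place of 2-fluorophenyl on a saturated ring carbon changes the read-out at all, and by how much, stays open.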